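Chloro for Fluoro on a Thiazolylidene Hydrazide

The compounds below may be only part of what the source reports. "The series", "measured", "known", "first", "only" and "open" are said of these compounds alone.

In a functional assay on C6 cells (Rattus norvegicus) for cytotoxicity, read by MTT assay, with a stated time of 24 h, tested at 6 ug/mL (a lower number here means a stronger effect, a higher number a weaker effect of the compound at the concentration tested), compound 1 `Cc1nnc(SCC(=O)N/N=c2/scc(-c3ccc(Cl)cc3)n2-c2ccccc2)s1` gives 82.8% and compound 2 `O=C(CSc1nnnn1-c1ccccc1)N/N=c1/scc(-c2ccc(F)cc2)n1-c1ccccc1` gives 74.9%, the lower of the two numbers, though the two lie within the scatter of each other. Compound 3 `O=C(CSc1nnnn1-c1ccccc1)N/N=c1/scc(-c2ccc(Cl)cc2)n1-c1ccccc1` has not yet been measured in this assay. It differs from compound 2 in one place: chloro in place of fluoro on an aromatic carbon. Among the measured compounds shown here, no step between measured compounds is available, so the step from compound 2 to compound 3 is expected to lie within the scatter, a number 3.1 percentage points higher from compound 2 to compound 3 (within the scatter), with no clear direction. Compound 3 is therefore estimated at 78%, between 62% and 92%.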

Compound 3, a percentage reported as activity, at one concentration (the size of the read-out at that concentration, not a potency): 77.4%
The estimate for compound 3 lay 0.6 percentage points above the measured number; the range from low to high includes it.
By their numbers in this assay, from the lowest: compounds 2, 3 and 1 (each within the scatter of the next).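

In this assay, the 4-fluorophenyl to 4-chlorophenyl change gives a number 2.5 percentage points higher from compound 2 to compound 3 (within the scatter), so this position tolerates either halogen without a change that can be told from the scatter. Among the compounds shown here, compound 3 also gives the first step on the sulfur, where 1-phenyl-1H-tetrazol-5-yl in place of 5-methyl-1,3,4-thiadiazol-2-yl gives a number 5.4 percentage points lower from compound 1 to compound 3 (within the scatter). Nothing shown gives a reason for either step. Open, from the compounds shown here alone, is whether a methoxy group or an amine on that aromatic carbon would move the read-out beyond the scatter. A carboxylic acid on the group held by the sulfur leaves the same question open there.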